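A few compounds are considered here, and "the series" means these few. Any claim that something is new, unique, unknown or untested is made for them only; others in the source may bear on it.

Working notes on the series

Three members of this series have been run in an ADME assay on BJ cells (Homo sapiens) for cytotoxicity, read by luminescence, with a stated time of 72 h (on this read-out lower numbers stand for an effect already at smaller amounts and higher numbers for an effect only at larger amounts of compound), and a fourth has not. Compound 1 is `CCOC(=O)c1c(-c2cccc(Br)c2)[nH]c2cc(OC)c(Cl)cc2c1=O`; compound 2 is `CCOC(=O)c1c(-c2cc(F)cc(OC)c2)[nH]c2cc(OC)c(Cl)cc2c1=O`; compound 3 is `CCOC(=O)c1c(-c2cccc(Br)c2)[nH]c2cc(OC)c(F)cc2c1=O`; compound 4 is `CCOC(=O)c1c(-c2cc(F)cc(OC)c2)[nH]c2cc(OC)c(F)cc2c1=O`.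

In this assay compound 1 reaches only the limit of the assay, > 21500 nM, and not a number. Compound 2 likewise sits at the limit, > 21500 nM. Compound 3 also returns only the limit, > 21500 nM.

Compound 1 differs from compound 2 as described: 3-fluoro-5-methoxyphenyl in place of 3-bromophenyl on an aromatic carbon. The step in this assay is a step that the two limits leave unreadable from compound 1 to compound 2. Compound 1 differs from compound 3 in the core: fluoro in place of chloro on an aromatic carbon, and the step here is a step that the two limits leave unreadable from compound 1 to compound 3. Neither step can be sized because of the limit of > 21500 nM in this assay, at which 3 of the 3 values shown sit.

Compound 4 stands to compound 3 as compound 2 stands to compound 1: 3-fluoro-5-methoxyphenyl in place of 3-bromophenyl on an aromatic carbon. The place is described in the same words in both cases, so this is the same change, made on the core of compound 3 rather than the core of compound 1.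

The expectation for compound 4 is that it remains at the limit, so the expected step is a step that the limit leaves unreadable from compound 3 to compound 4, resting on compound 3 giving > 21500 nM and on the earlier change returning only the limit in a step that the two limits leave unreadable from compound 1 to compound 2. The estimate for compound 4 is 30000 nM, with a range from 15000 nM to 80000 nM.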

Compound 4, half-maximal effective concentration: > 21500 nM
Compound 4: no number, only a limit (the forecaster's own chance of this, stated with the estimate: 85%); the middle value lies beyond the limit too.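

No new step can be read in this assay: the steps from compound 3 to compound 4 and from compound 2 to compound 4 cannot be sized, because the values stop at a limit: the limit of > 21500 nM in this assay, at which 4 of the 4 values shown sit.

The compounds shown leave open whether 3-fluoro-5-methoxyphenyl in place of 3-bromophenyl, or fluoro in place of chloro, changes the read-out at all, and at what concentration any of them would give an effect.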